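The compounds below may be only part of what the source reports. "The series", "measured", "known", "first", "only" and "open" are said of these compounds alone.

Compound 3 `CC1CCN(c2c(S(=O)(=O)c3ccc(C#N)cc3)cnc3cc(F)ccc23)CC1` gives 83% in an assay on isolated protein for displacement of a labelled ligand from metabotropic glutamate receptor 5 (Homo sapiens), with a stated time of 60 min, tested at 1 uM (a lower number here means less inhibition, a higher number more inhibition at the concentration tested (going by the name of the read-out)), second highest of the three numbers recorded there; compound 1 `COCC1CCN(c2c(S(=O)(=O)c3ccc(F)cc3)cnc3cc(F)ccc23)CC1` gives 76.1% and compound 2 `Cc1ccc(S(=O)(=O)c2cnc3cc(F)ccc3c2N2CCC(C)CC2)cc1Cl` gives 93%, both within the usual scatter of compound 3. Compound 4 `CC1CCN(c2c(S(=O)(=O)c3ccc(F)cc3)cnc3cc(F)ccc23)CC1` arises from compound 3 by fluoro in place of cyano on an aromatic carbon. For the measured compounds named here, the only measured step at the same position, a number 10 percentage points lower from compound 2 to compound 3 (within the scatter), lay within the scatter, and compound 1, which already carries the 4-fluorophenyl on its sulfonyl sulfur, shows a value close to that of compound 3. The expected change for compound 4 is therefore a number 4 percentage points lower from compound 3 to compound 4 (within the scatter), no shift beyond the scatter. Compound 4 is estimated at 79%, within a range from 66% to 91%.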

Compound 4, a percentage reported as inhibition, at one concentration (the size of the read-out at that concentration, not a potency): 74.5%
Compound 4: the middle estimate sits 4.5 percentage points above what was measured, and the stated range covers the measured number.
By their numbers in this assay, from the lowest: compounds 4, 1, 3 and 2 (each within the scatter of the next, the first and the last beyond it).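

In this assay, fluoro in place of cyano on the aromatic carbon gives a number 8.5 percentage points lower from compound 3 to compound 4 (within the scatter), and hydrogen in place of methoxy on the chain gives a number 1.6 percentage points lower from compound 1 to compound 4 (within the scatter). The sulfonyl substituent now shows its first step beyond the scatter, though a modest one: 4-fluorophenyl in place of 3-chloro-4-methylphenyl gives a number 18.5 percentage points lower from compound 2 to compound 4 (beyond the scatter). No evidence on the cause of these steps is available. Open remain other groups on that aromatic carbon, such as an amine or a carboxylic acid, and whether the chloro or the methyl of the 3-chloro-4-methylphenyl accounts for that step.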